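A few compounds are considered here, and "the series" means these few. Any claim that something is new, unique, unknown or untested is made for them only; others in the source may bear on it.

Three compounds share one core and differ only in the group on a carbonyl carbon. Compound 1 `COc1ccc(/C=C/c2cc(OC)cc(OC)c2/C=C/C(=O)NC2CC2)cc1` carries cyclopropylamino there; in a functional assay on A549 cells (Homo sapiens) for inhibition, read by MTT assay, with a stated time of 48 h (a lower number here means a stronger inhibitor, a higher number a weaker inhibitor), compound 1 gives 8810 nM. Compound 2 `COc1ccc(/C=C/c2cc(OC)cc(OC)c2/C=C/C(=O)N2CCN(C)CC2)cc1` carries 4-methylpiperazin-1-yl, and in this assay compound 2 gives 4510 nM. Compound 3 `COc1ccc(/C=C/c2cc(OC)cc(OC)c2/C=C/C(=O)N2CCCC2)cc1` carries pyrrolidin-1-yl; in this assay compound 3 gives 6350 nM. Of these three numbers, that of compound 2 is the lowest, yet every gap stays within the scatter: a 2.0-fold lower number from compound 1 to compound 2 (0.29 log units; within the scatter), a 1.4-fold higher number from compound 2 to compound 3 (0.15 log units; within the scatter), and also a 1.4-fold lower number from compound 1 to compound 3 (0.14 log units; within the scatter).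

Compound 4 `CCCCCN(CCCCC)C(=O)/C=C/c1c(/C=C/c2ccc(OC)cc2)cc(OC)cc1OC` has not yet been measured. It differs from compound 2 only at that carbonyl carbon: dipentylamino in place of 4-methylpiperazin-1-yl on a carbonyl carbon. Every exchange made so far at this position has shifted the number by less than the scatter, so a further exchange there is expected to behave alike, even though dipentylamino brings no ring and no hydrogen-bond acceptor. In this assay compound 4 is therefore expected to give 5500 nM, within a range from 2000 nM to 16000 nM. The expected step of a 1.2-fold higher number from compound 2 to compound 4 (0.09 log units; within the scatter) is estimated to lie within the scatter.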

Compound 4, half-maximal inhibitory concentration: 7490 nM
Compound 4: the middle estimate sits 1.4-fold (0.13 log units) below what was measured; low and high end bracket the measured number.
By their numbers in this assay, from the lowest: compounds 2, 3, 4 and 1 (each within the scatter of the next).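

Dipentylamino brings a longer, open group with no ring and no hydrogen-bond acceptor, yet swapping it in for 4-methylpiperazin-1-yl gives a 1.7-fold higher number from compound 2 to compound 4 (0.22 log units; within the scatter) in this assay. The comparisons with the two other groups tell the same story, with a 1.2-fold higher number from compound 3 to compound 4 (0.07 log units; within the scatter) and a 1.2-fold lower number from compound 1 to compound 4 (0.07 log units; within the scatter). Across these four compounds, then, neither a ring nor a hydrogen-bond acceptor in the group on this carbonyl carbon is needed for a number in this range, and the earlier compounds, which all carry a ring in that group, could not show this.

Nothing available here explains why the numbers stay so close. On these data alone, it remains open whether a group of another kind on this carbonyl carbon, such as a carboxylic acid or a primary amine, would move the number beyond the scatter.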